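Chloro on the benzoyl: compound 2 to compound 4

This account rests on a few compounds, and the source may have more. Where it says the series, first, only, none or still open, it means among the compounds named here.

Of the compounds shown here, three have been measured. Compound 1 `O=C(Nc1ccccc1C(F)(F)F)C1CCc2ccccc2N1C(=O)c1ccccc1` gives 5290 nM in a functional assay on MDA-MB-231 cells (Homo sapiens) for cytotoxicity, read by sulforhodamine B assay, with a stated time of 72 h; on this read-out higher numbers stand for weaker inhibition of growth and lower numbers for stronger inhibition of growth. Compound 2 `O=C(Nc1ccccc1O)C1CCc2ccccc2N1C(=O)c1ccccc1` gives 4210 nM in this assay, and compound 3 `O=C(Nc1cc(C(F)(F)F)cc(C(F)(F)F)c1)C1CCc2ccccc2N1C(=O)c1ccccc1` gives 2430 nM. Compound 2 stands second highest of the three numbers; the step of a 1.3-fold lower number from compound 1 to compound 2 (0.10 log units; within the scatter) lies within the scatter, and the gap from compound 2 to compound 3 is within the scatter too, so the three measured compounds are not separated on this read-out.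

Compound 4 `O=C(Nc1ccccc1O)C1CCc2ccccc2N1C(=O)c1ccc(Cl)cc1` differs from compound 2 by chloro in place of hydrogen on an aromatic carbon. Among the measured compounds shown here, none of the measured compounds differs from another on the benzoyl, so no measured step bears directly on this change; the changes that were measured sit elsewhere in the molecule, and none of them moved the number beyond the scatter. There is thus no ground for expecting a shift in either direction. Compound 4 is expected to give 4000 nM, with a range of 1500 nM to 11000 nM. The step of a 1.1-fold lower number from compound 2 to compound 4 (0.02 log units; within the scatter) is expected to stay within the scatter.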

Compound 4, concentration for 50% growth inhibition: 19600 nM
For compound 4 the middle estimate is 4.9-fold (0.69 log units) below the measured one; the measured number lies above the stated range.
By their numbers in this assay, from the lowest: compounds 3, 2 and 1 (each within the scatter of the next, the first and the last beyond it); then compound 4.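

In this assay, among the compounds shown here, the benzoyl ring is the first place where a single change moves the number beyond the scatter: phenyl to 4-chlorophenyl gives a 4.7-fold higher number from compound 2 to compound 4 (0.67 log units; beyond the scatter), a modest step towards weaker inhibition of growth. For the compounds shown here, the one earlier single-place step, hydroxy in place of trifluoromethyl elsewhere in the molecule, gave a 1.3-fold lower number from compound 1 to compound 2 (0.10 log units; within the scatter), so in these two pairs only the change on the benzoyl separates the compounds. Nothing at hand accounts for this step.

One pair cannot tell whether the shift belongs to chloro itself or to any group at this place on the ring. A methoxy group, an amine or a carboxylic acid at the same place, or chloro on the benzoyl of compound 3, would help to separate these readings.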